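Cytotoxicity Limits Across a Small Series of Related Analogues

The source may report more compounds than this note shows. Statements on the series, on what has been measured and on what is new or still open speak of the compounds shown alone.

The measured set consists of compound 1 `Cc1nc(C(NC(=O)C(=O)Nc2ccc(F)cc2F)C2CCCCN2)sc1CO`, compound 2 `CC(=O)c1ccc(NC(=O)C(=O)NC(c2nc(C)c(CCO)s2)C2CCCCN2)cc1` and compound 3 `Cc1nc(C(NC(=O)C(=O)Nc2ccc(F)c(Cl)c2)C2CCCCN2)sc1CO`, while compound 4 `Cc1nc(C(NC(=O)C(=O)NC2CCCCCC2)C2CCCCN2)sc1CCO` has not yet been tested. In an ADME assay on TZM-b1 cells (Homo sapiens) for cytotoxicity, read by XTT assay, with a stated time of 3 days (on this read-out lower numbers stand for higher toxicity in this test and higher numbers for lower toxicity in this test), compound 1 reaches only a limit, > 87000 nM. Compound 3 likewise gives only a limit in this assay, namely > 77800 nM. The step that the two limits leave unreadable from compound 1 to compound 3 therefore cannot be sized. Compound 2, the point of departure here, also stands at a limit in this assay, > 77300 nM. Every value shown is such a limit: the limit of > 77300 nM in this assay, at which 1 of the 3 values shown sits, the limit of > 77800 nM in this assay, at which 1 of the 3 values shown sits, and (the limit of > 87000 nM in this assay, at which 1 of the 3 values shown sits). The change from compound 2 to compound 4 is cycloheptyl in place of 4-acetylphenyl on an amide-type nitrogen. Among the compounds with values here, no measured step bears on this change, and the only step among the measured compounds is unreadable because both ends are limits. Given that every measured compound sits at a limit, compound 4 is expected to do the same, with an estimated step that the limit leaves unreadable from compound 2 to compound 4, that is no shift beyond the scatter. The estimated value for compound 4 is 80000 nM, expected to lie between 40000 nM and 200000 nM.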

Compound 4, half-maximal cytotoxic concentration: > 88000 nM
Compound 4: only a limit was reported; the forecaster's own chance of this, stated with the estimate: 80%; middle value at least 1.1-fold (0.04 log units) from the limit.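

In this assay compound 4 gives only a limit, > 88000 nM. Compound 2 also stands at a limit, so no size can be read for the change between compound 2 and compound 4. The compounds shown leave open where the half-maximal cytotoxic concentration of any of these four compounds lies.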